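One more methyl on compound 2

The compounds below may be only part of what the source reports. "The series", "measured", "known", "first", "only" and "open" are said of these compounds alone.

Compound 1 `CCC(C)Sc1nc(O)cc(Cc2c(F)cccc2F)n1`: > 200000 nM (a limit)
Compound 2 `CCC(C)Sc1nc(O)cc(C(C)c2c(F)cccc2F)n1`: > 200000 nM (a limit)

In a functional assay on MT4 cells (Homo sapiens) for cytotoxicity (a higher number here means that more compound is tolerated, a lower number that less compound is tolerated), compound 2 gives > 200000 nM, which is a limit and not a number. That makes its true position unknown, and the same holds for compound 1: the limit of > 200000 nM in this assay, at which 2 of the 2 values shown sit.

Compound 3 `CCC(C)Sc1nc(O)c(C)c(C(C)c2c(F)cccc2F)n1` carries a methyl in place of hydrogen on an aromatic carbon, ortho to a hydroxy group (methyl in place of hydrogen on an aromatic carbon).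

Within the data shown here, the only measured step that bears on this change is a step that the two limits leave unreadable from compound 1 to compound 2. It also adds a methyl, though at a different place, and it offers no size to carry over. A step beyond the usual scatter is therefore not expected in this assay, and another limit is the likeliest report. The estimated step is an at least 1.1-fold lower number from compound 2 to compound 3 (0.04 log units; that floor lies within the scatter). For compound 3 the expected value is 180000 nM, with an estimated range from 70000 nM to 200000 nM.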

Compound 3, half-maximal cytotoxic concentration: > 200000 nM
Compound 3 was reported as a limit; the forecaster's own chance of this, stated with the estimate: 75%; middle value at least 1.1-fold (0.04 log units) away from the limit.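

Compound 2 and compound 3 are both reported only as limits, so no size can be read for the added methyl: the limit of > 200000 nM in this assay, at which 3 of the 3 values shown sit.

The compounds shown leave open how much of each is actually tolerated in this assay, and whether either added methyl shifts that number at all.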